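Working notes: benzyl to 2-nitrophenyl on the shared core

The compounds below may be only part of what the source reports. "The series", "measured", "known", "first", "only" and "open" are said of these compounds alone.

Measured so far:
- compound 1 `CC1(C)O[C@H]2O[C@H]([C@@H](CCO)n3cnc4c(N)ncnc43)[C@H](Oc3ccccc3[N+](=O)[O-])[C@H]2O1` gives 51800 nM
- compound 2 `CC1(C)O[C@H]2O[C@H]([C@H](CCO)n3cnc4c(N)ncnc43)[C@H](OCc3ccccc3)[C@H]2O1` gives 97100 nM

Among the measured compounds shown here, in an ADME assay on Vero cells (Chlorocebus sabaeus) for cytotoxicity, read by fluorescence and resazurin assay, with a stated time of 3 days (a lower number here means that less compound is tolerated, a higher number that more compound is tolerated), compound 2 at 97100 nM lies within the scatter of compound 1, the only other measured compound, so the pair sets no order. Next is compound 3 `CC1(C)O[C@H]2O[C@H]([C@H](CCO)n3cnc4c(N)ncnc43)[C@H](Oc3ccccc3[N+](=O)[O-])[C@H]2O1` with 2-nitrophenyl in place of benzyl on an oxygen on a saturated carbon. For the measured compounds named here, no step between measured compounds is available to size this change. Compound 1 also carries the 2-nitrophenyl group, and compound 1 at 51800 nM is the only reference for it. In this assay a small move to a lower number is expected, perhaps none beyond the scatter (a 1.6-fold lower number from compound 2 to compound 3 (0.21 log units; within the scatter)). For compound 3 the estimated value is 60000 nM (expected range 28000 nM to 125000 nM).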

Compound 3, half-maximal cytotoxic concentration: 148000 nM
Compound 3: the middle estimate sits 2.5-fold (0.39 log units) below what was measured; the whole stated range lies below it.
By their numbers in this assay, from the lowest: compounds 1, 2 and 3 (each within the scatter of the next, the first and the last beyond it).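

With the 2-nitrophenyl group held constant, this assay gives a 2.9-fold higher number from compound 1 to compound 3 (0.46 log units; beyond the scatter), a modest step that can be placed on the stereocentre at the saturated chain carbon, drawn R in compound 1 and S in compound 3, because no other feature changes: the fact that compounds 1 and 3 differ only in the configuration as drawn. Benzyl to 2-nitrophenyl on an oxygen on a saturated carbon can now be sized, with the chain configuration kept, and it gives a 1.5-fold higher number from compound 2 to compound 3 (0.18 log units; within the scatter), so the two groups are not told apart at this position. Among the compounds shown here, of these two single changes, only the one in configuration lies beyond the scatter.

From the compounds shown here alone, whether the configuration step also holds with benzyl on that oxygen remains open. Also open, going by these compounds, is how an amine or a carboxylic acid in place of 2-nitrophenyl would read in this assay.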